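Replacing One Chlorinated Side Group on an Aromatic Ring

The compounds below may be only part of what the source reports. "The series", "measured", "known", "first", "only" and "open" are said of these compounds alone.

For the measured compounds named here, in a functional assay on MCF7 cells (Homo sapiens) for cytotoxicity, read by sulforhodamine B assay, with a stated time of 72 h (a higher number here means a weaker inhibitor, a lower number a stronger inhibitor), compound 1 `O=C(Nc1ccc(Nc2ncnc3c2cnn3-c2ccccc2)cc1)Nc1cccc(Cl)c1` gives 4200 nM, the higher of the two numbers known so far. Compound 2 `O=c1sc2cc(Nc3ncnc4c3cnn4-c3ccccc3)ccc2n1Cc1ccc(Cl)c(Cl)c1` gives 1600 nM, and the gap between the two lies beyond the usual scatter. Compound 3 `Clc1ccc(COc2ccc(Nc3ncnc4c3cnn4-c3ccccc3)cc2)cc1` has not yet been measured. It keeps the core of compound 1 but has (4-chlorobenzyl)oxy in place of ((3-chlorophenyl)carbamoyl)amino on an aromatic carbon. Going by the values given here, no measured pair shows a swap of this kind, so any forecast is rough. Like compound 3, compound 2 carries a chlorinated benzyl group and gives 1600 nM, so a modest move toward a lower number is expected in this assay. The expected change is a 1.7-fold lower number from compound 1 to compound 3 (0.23 log units; within the scatter), which stays within the scatter. For compound 3 the estimate is 2500 nM, with an expected range of 700 nM to 9000 nM.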

Compound 3, half-maximal inhibitory concentration: 4360 nM
For compound 3 the middle estimate is 1.7-fold (0.24 log units) below the measured one, and the stated range covers the measured number.
By their numbers in this assay, from the lowest: compound 2; then compounds 1 and 3 (each within the scatter of the next).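

In this assay, (4-chlorobenzyl)oxy in place of ((3-chlorophenyl)carbamoyl)amino gives a 1.0-fold higher number from compound 1 to compound 3 (0.02 log units; within the scatter), the first step seen at this position, on an aromatic carbon para to a large group. The group that leaves has 2 hydrogen-bond donors and the group that enters has 0, yet the numbers of the two compounds cannot be told apart here, so in this pair the urea-type linker with its donors is not needed to keep the number where it is. Nothing on hand explains why these two different groups read alike.

As far as these compounds go, it remains open how a side group without a chlorinated aromatic ring, such as a carboxylic acid or an amine, would read at this position. From the compounds shown here alone, a longer chain between the oxygen and the chlorinated ring is equally open.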